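The compounds below may be only part of what the source reports. "The series", "measured", "known", "first", "only" and "open" are said of these compounds alone.

Measured compounds:
- compound 1, `O=C(/C=C/c1ccc(OCc2cn(Cc3cccc(Br)c3)nn2)cc1)c1ccc(Br)cc1`: 43%
- compound 2, `O=C(/C=C/c1ccc(OCc2cn(Cc3ccc(Br)cc3)nn2)cc1)c1ccc(Br)cc1`: 29%
- compound 3, `O=C(/C=C/c1ccc(OCc2cn(Cc3cccc(F)c3)nn2)cc1)c1ccc(Br)cc1`: 34%

In a functional assay on MIA PaCa-2 cells (Homo sapiens) for inhibition, read by MTT assay, with a stated time of 48 h, tested at 10 uM (on this read-out lower numbers stand for less inhibition of growth and higher numbers for more inhibition of growth at the one concentration tested), compound 2 gives the lowest of the three numbers. Its gap to compound 3 lies within the scatter, as a number 5 percentage points higher from compound 2 to compound 3 (within the scatter) shows, while the step of a number 14 percentage points lower from compound 1 to compound 2 (beyond the scatter) is beyond it, so compound 2 stands below compound 1 but cannot be separated from compound 3.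

Compound 4, `COc1ccc(C(=O)/C=C/c2ccc(OCc3cn(Cc4ccc(Br)cc4)nn3)cc2)cc1`, is not yet measured. It differs from compound 2 by methoxy in place of bromo on an aromatic carbon, a change on the carbonyl side of the shared core rather than on the benzyl side where the three measured compounds vary.

Among the compounds with values here, no measured step touches this position. The nearest comparison is the halogen swap a number 9 percentage points lower from compound 1 to compound 3 (within the scatter) on the other ring, which stayed within the scatter. Within the data shown here, the replacement of bromo by methoxy has no precedent in these data, so no step beyond the scatter is expected in either direction.

Compound 4 is estimated at 30%, with a range from 12% to 48%. This corresponds to an expected step of a number 1 percentage points higher from compound 2 to compound 4 (within the scatter).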

Compound 4, percent growth inhibition at one concentration: 56%
Beside the measured number, compound 4's estimate is 26 percentage points below it; the measured number lies above the stated range.
By their numbers in this assay, from the lowest: compounds 2, 3 and 1 (each within the scatter of the next, the first and the last beyond it); then compound 4.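

Methoxy in place of bromo at this position, on an aromatic carbon para to a large group, gives a step beyond the scatter in this assay: a number 27 percentage points higher from compound 2 to compound 4 (beyond the scatter). The earlier compounds shown here varied only the benzyl side, and this result shows that the carbonyl side of the shared core also moves the number, here towards more inhibition of growth at the one concentration tested. Nothing given here bears on why the number rises with this change.

Only bromo and methoxy are shown at this position, and it remains open how a hydroxyl, an amine or a longer chain such as ethoxy would read there. As far as these compounds go, it also remains open whether methoxy would give a similar step with the benzyl groups of compound 1 or compound 3.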